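This account rests on a few compounds, and the source may have more. Where it says the series, first, only, none or still open, it means among the compounds named here.

Measured compounds:
compound 1, `COc1cc(/C=C/C(=O)CC(=O)/C=C/c2ccc(OCCO)c(OC)c2)ccc1O`: 25000 nM
compound 2, `COc1cc(/C=C/C(=O)CC(=O)/C=C/c2ccc(OCCO)cc2)ccc1O`: 46000 nM
compound 3, `COc1cc(/C=C/C(=O)CC(=O)/C=C/c2ccc(OC(C)=O)c(OC)c2)ccc1OC(C)=O`: 80000 nM

All three values come from an ADME assay on HEK293 cells (Homo sapiens) for cytotoxicity, read by resazurin assay, with a stated time of 16 h; on this read-out higher numbers stand for an effect only at larger amounts of compound and lower numbers for an effect already at smaller amounts. Compound 1 and compound 2 share a core and differ in one place: hydrogen in place of methoxy on an aromatic carbon. This gives a 1.8-fold higher number from compound 1 to compound 2 (0.26 log units; within the scatter). Compound 3 stands at the high end of the three numbers; its gap to compound 2 lies within the scatter, its gap to compound 1 beyond it. The difference between the core of compound 3 and the core of compound 1 is not broken down here.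

Compound 4, `COc1cc(/C=C/C(=O)CC(=O)/C=C/c2ccc(OC(C)=O)cc2)ccc1OC(C)=O`, is not yet measured. It differs from compound 3 in one place: hydrogen in place of methoxy on an aromatic carbon. The surroundings of the place are not identical: in compound 1 the methoxy sits ortho to a 2-hydroxyethoxy group, in compound 3 ortho to an acetoxy group, so the change from compound 3 to compound 4 is the same kind of change as from compound 1 to compound 2, not the same. For compound 4 in this assay the step of a 1.4-fold higher number from compound 3 to compound 4 (0.14 log units; within the scatter) is expected. This rests on the earlier step, a 1.8-fold higher number from compound 1 to compound 2 (0.26 log units; within the scatter), made by the same kind of change. The estimate for compound 4 is 110000 nM, with a range from 60000 nM to 220000 nM.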

Compound 4, half-maximal effective concentration: 49000 nM
The estimate for compound 4 lay 2.2-fold (0.35 log units) above the measured number, outside the stated range (below it).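

In this assay, hydrogen in place of methoxy on an aromatic carbon gives a 1.6-fold lower number from compound 3 to compound 4 (0.21 log units; within the scatter), and this does not match the earlier step on the other core: the same change on two cores in this assay, a 1.8-fold higher number (0.26 log units; within the scatter) from compound 1 to compound 2 and a 1.6-fold lower number (0.21 log units; within the scatter) from compound 3 to compound 4, 3.0-fold (0.48 log units) apart, beyond the scatter of two such steps. The change therefore does not carry as one fixed step between the core of compound 1 and the core of compound 3, and a step read on one of these cores is a weak guide to the other. This does not show what sets the two steps apart, since each rests on a single pair and lies within the scatter on its own, so only the gap between them goes beyond it.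

Still open, as far as these compounds go, is how the same change behaves when the group ortho to the methoxy is neither acetoxy nor 2-hydroxyethoxy but, for example, a carboxylic acid, an amine or a longer chain. Also open, from the compounds shown here alone, is whether the two steps stay apart on further pairs of cores.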